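The source may hold more compounds than are shown below. What is called first, only, known or untested is meant among the compounds shown, and "the series" means these compounds.

Working notes on the series. Three compounds have numbers in an assay on HEK293 cells for displacement of a labelled ligand from 5-hydroxytryptamine receptor 6 (Homo sapiens), read by radioligand binding, with a stated time of 1 h; a higher number here means a weaker inhibitor, a lower number a stronger inhibitor. Compound 1 `Cc1ccc(C(C)C)c(OCc2nc(N)nc(N3CCN(C)CC3)n2)c1` gives 11 nM. Compound 2 `Cc1ccccc1OCc1nc(N)nc(N2CCN(C)CC2)n1` gives 87 nM, which is the second highest of the three, the nearest being compound 1 and the furthest compound 3. Compound 3 `Cc1cc(Cl)ccc1OCc1nc(N)nc(N2CCN(C)CC2)n1` gives 911 nM. Going by the values given here, the only single-point step among them is a 10-fold higher number from compound 2 to compound 3 (1.02 log units; beyond the scatter), a chloro in place of a hydrogen on an aromatic carbon.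

Compound 4 `Cc1cc(OCc2nc(N)nc(N3CCN(C)CC3)n2)ccc1Cl` is not yet measured. It differs from compound 2 by 4-chloro-3-methylphenyl in place of 2-methylphenyl on an oxygen on a saturated carbon. The step that bears on it is the chloro addition from compound 2 to compound 3, which raised the number well beyond the scatter; compound 4 carries the same chlorine but with the methyl on a different carbon of the ring, and nothing measured isolates the effect of moving the methyl. On that basis the step from compound 2 to compound 4 in this assay is expected to be a 5.7-fold higher number from compound 2 to compound 4 (0.76 log units; beyond the scatter), toward a weaker inhibitor. Compound 4 is therefore estimated at 500 nM, with a range from 150 nM to 2000 nM.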

Compound 4, inhibition constant: 355 nM
For compound 4 the middle estimate is 1.4-fold (0.15 log units) above the measured one; the measured number falls inside the stated range.
By their numbers in this assay, from the lowest: compound 1; then compound 2; then compound 4; then compound 3.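

Going by these compounds alone, with the chlorine held constant, 4-chloro-3-methylphenyl in place of 4-chloro-2-methylphenyl gives a 2.6-fold lower number from compound 3 to compound 4 (0.41 log units; beyond the scatter) in this assay, so the placing of the methyl on the ring moves the number beyond the scatter, which the earlier compounds could not show. Measured against the unchlorinated 2-methylphenyl, the change still gives a 4.1-fold higher number from compound 2 to compound 4 (0.61 log units; beyond the scatter), so both chlorine-bearing compounds stand on the weaker side of compound 2 whichever carbon holds the methyl. Nothing available explains either step.

Within the data shown here, how much of the step to compound 4 belongs to the chlorine and how much to the moved methyl stays open, as no compound here carries the chlorine without the methyl. Also open, going by these compounds, is whether methoxy or a nitrile in place of the chlorine would raise the number in the same way.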